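A few compounds are considered here, and "the series" means these few. Any claim that something is new, unique, unknown or untested is made for them only; others in the source may bear on it.

Among the measured compounds shown here, in a functional assay (plasma) with Oryctolagus cuniculus as the target (a lower number here means a stronger inhibitor, a higher number a weaker inhibitor), three compounds built on a shared core have numbers so far. Compound 1 `Cc1nc2cnccc2n1CC1CCN(C(=O)CCc2ccccc2)CC1` gives 60 nM, compound 2 `COc1ccccc1CCC(=O)N1CCC(Cn2c(C)nc3cnccc32)CC1` gives 15 nM, and compound 3 `Cc1nc2cnccc2n1CC1CCN(C(=O)CC(C)(O)c2ccccc2)CC1` gives 6.9 nM. Compound 3 therefore has the lowest number of the three and is the strongest inhibitor among them.

Compound 4 `Cc1nc2cnccc2n1CC1CCN(C(=O)CN(C)c2ccccc2)CC1` differs from compound 3 in one place: methyl(phenyl)amino in place of 1-hydroxy-1-phenylethyl on a saturated chain carbon bound to a carbonyl carbon. The entering group still has a phenyl and a methyl, but the hydroxy group of compound 3 is gone.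

For the measured compounds named here, two measured steps bear most directly on this change, since each ends at compound 3 and starts from a compound without that hydroxy group. The first is an 8.7-fold lower number from compound 1 to compound 3 (0.94 log units; beyond the scatter), and the second is a 2.2-fold lower number from compound 2 to compound 3 (0.34 log units; beyond the scatter). A third, a 4.0-fold lower number from compound 1 to compound 2 (0.60 log units; beyond the scatter), shows that a compound without the hydroxy group can still reach a fairly low number. Neither compound 1 nor compound 2 carries methyl(phenyl)amino, so these steps offer only indirect guidance, and a modest loss seems more likely than a large one.

The expected step is a 3.6-fold higher number from compound 3 to compound 4 (0.56 log units; beyond the scatter), towards a weaker inhibitor. For compound 4 the estimated value is 25 nM, with an expected range from 7 nM to 90 nM.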

Compound 4, half-maximal inhibitory concentration: 23 nM
For compound 4 the middle estimate is 1.1-fold (0.04 log units) above the measured one; measured number inside the range.
By their numbers in this assay, from the lowest: compound 3; then compounds 2 and 4 (each within the scatter of the next); then compound 1.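

In this assay, methyl(phenyl)amino gives a 3.3-fold higher number from compound 3 to compound 4 (0.52 log units; beyond the scatter), so at this saturated chain carbon bound to a carbonyl carbon it falls short of 1-hydroxy-1-phenylethyl, the group that carries a hydrogen-bond donor. It still beats the plain benzyl group, with a 2.6-fold lower number from compound 1 to compound 4 (0.42 log units; beyond the scatter), which shows that a group with no hydrogen-bond donor and a nitrogen attached to the phenyl ring can lower the number at this place. Against 2-methoxybenzyl there is a 1.5-fold higher number from compound 2 to compound 4 (0.19 log units; within the scatter), so these two groups cannot be told apart here, and compound 4 joins compound 2 as a second compound without a hydroxy group that improves on compound 1 but stays behind compound 3.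

No measurement shown explains why these groups rank as they do. The compounds shown also leave open what a carboxylic acid or a longer chain would do at this place, and whether a secondary amine, with the methyl of methyl(phenyl)amino replaced by hydrogen, would keep the number of compound 4.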